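A Second Fluorine on the Aryl Ring of Compound 3

The source may report more compounds than this note shows. Statements on the series, on what has been measured and on what is new or still open speak of the compounds shown alone.

Compound 1 `Cc1ccc(-n2nc(C(=O)Nc3ccc(Oc4ncnc5ccsc45)cc3)c(C)cc2=O)cc1`, compound 2 `Cc1ccc(-n2nc(C(=O)Nc3ccc(Oc4ncnc5ccsc45)c(F)c3)c(C)cc2=O)cc1` and compound 3 `Cc1cc(=O)n(-c2ccc(F)cc2)nc1C(=O)Nc1ccc(Oc2ncnc3ccsc23)c(F)c1` were tested in a functional assay on HepG2 cells (Homo sapiens) for cytotoxicity, read by MTT assay, with a stated time of 72 h; on this read-out higher numbers stand for weaker inhibition and lower numbers for stronger inhibition. In this assay compound 1 gives 25000 nM, compound 2 gives 17300 nM and compound 3 gives 470 nM. The change from compound 1 to compound 2 is fluoro in place of hydrogen on an aromatic carbon, and it made a 1.4-fold lower number from compound 1 to compound 2 (0.16 log units; within the scatter). The change from compound 2 to compound 3 made a 37-fold lower number from compound 2 to compound 3 (1.57 log units; beyond the scatter); the difference between the cores of compound 1 and compound 3 is not broken down here. Compound 4 `Cc1cc(=O)n(-c2ccc(F)c(F)c2)nc1C(=O)Nc1ccc(Oc2ncnc3ccsc23)c(F)c1` has not yet been measured; it differs from compound 3 by fluoro in place of hydrogen on an aromatic carbon. For the measured compounds named here, this is the same kind of change as the one from compound 1 to compound 2, but the surroundings differ: in compound 4 the entering fluoro sits ortho to a fluoro group, whereas in compound 2 it sits ortho to a large group. Because the earlier step of a 1.4-fold lower number from compound 1 to compound 2 (0.16 log units; within the scatter) stayed within the scatter, compound 4 is expected to show a 1.2-fold lower number from compound 3 to compound 4 (0.07 log units; within the scatter) in this assay. The estimate for compound 4 is 400 nM, with a range from 150 nM to 1200 nM.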

Compound 4, half-maximal inhibitory concentration: 6930 nM
Estimate against measurement, compound 4: 17-fold (1.24 log units) below; measured number above the stated range.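

Fluoro in place of hydrogen on an aromatic carbon did not carry over from one core to the other in this assay: the same change on two cores in this assay, a 1.4-fold lower number (0.16 log units; within the scatter) from compound 1 to compound 2 and a 15-fold higher number (1.17 log units; beyond the scatter) from compound 3 to compound 4, 21-fold (1.33 log units) apart, beyond the scatter of two such steps. On the 4-fluorophenyl group, ortho to a fluoro group, the change gave a 15-fold higher number from compound 3 to compound 4 (1.17 log units; beyond the scatter), and the other listed comparison, 3,4-difluorophenyl in place of 4-methylphenyl, gave a 2.5-fold lower number from compound 2 to compound 4 (0.40 log units; beyond the scatter), so the 3,4-difluorophenyl group keeps only a modest part of the large step seen with the 4-fluorophenyl group. This shows that the step on one core did not foretell the step on the other in this series, but it does not show why, as there is one pair per core and the two pairs differ in both the core and the surroundings of the entering fluoro.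

The compounds shown leave open how chloro, methoxy or an amine in the same place on the 4-fluorophenyl group would read. They also leave open whether a fluoro entering the 4-methylphenyl group of compound 2 would move the number in the same way.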